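A few compounds are considered here, and "the series" means these few. Any claim that something is new, unique, unknown or untested is made for them only; others in the source may bear on it.

Measured so far in an ADME assay on MRC5 cells (Homo sapiens) for cytotoxicity, read by MTT assay, with a stated time of 24 h; on this read-out higher numbers stand for lower toxicity in this test and lower numbers for higher toxicity in this test:
compound 1 `CC1(C)[C@H]2CC[C@]1(C)N(Cc1cn(-c3ccc(C#N)cc3)nn1)C(=O)C2` gives 10800 nM
compound 2 `CC1(C)[C@H]2CC[C@]1(C)N(Cc1cn(-c3ccccc3C#N)nn1)C(=O)C2` gives 23300 nM
compound 3 `CC1(C)[C@H]2CC[C@]1(C)N(Cc1cn(-c3ccccc3Cl)nn1)C(=O)C2` gives 4130 nM

Compound 3 holds the lowest number of the three: the steps of a 2.6-fold lower number from compound 1 to compound 3 (0.42 log units; beyond the scatter) and a 5.6-fold lower number from compound 2 to compound 3 (0.75 log units; beyond the scatter) are both beyond the scatter, so on these numbers it is the most cytotoxic of the set. Compound 4 `CC1(C)[C@H]2CC[C@]1(C)N(Cc1cn(-c3cccc(Br)c3)nn1)C(=O)C2` differs from it by 3-bromophenyl in place of 2-chlorophenyl on an aromatic nitrogen. Among the compounds with values here, no measured step exchanges one halogen for another or moves a halogen around the ring; the nearest guidance is the positional move of the nitrile, a 2.2-fold higher number from compound 1 to compound 2 (0.33 log units; beyond the scatter), and the halogen-for-nitrile exchange, a 5.6-fold lower number from compound 2 to compound 3 (0.75 log units; beyond the scatter), both modest. A modest step in this assay is therefore expected, most likely a somewhat higher number than compound 3. Compound 4 is estimated at 6000 nM, with a range of 2500 nM to 15000 nM, that is a 1.5-fold higher number from compound 3 to compound 4 (0.16 log units; within the scatter).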

Compound 4, half-maximal cytotoxic concentration: 38800 nM
For compound 4 the middle estimate is 6.5-fold (0.81 log units) below the measured one, outside the stated range (above it).
By their numbers in this assay, from the lowest: compound 3; then compound 1; then compounds 2 and 4 (each within the scatter of the next).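

In this assay the change to 3-bromophenyl gives a 9.4-fold higher number from compound 3 to compound 4 (0.97 log units; beyond the scatter) as the largest step yet at this aromatic nitrogen, so a halogen on the phenyl does not by itself hold the number low. The same group gives a 3.6-fold higher number from compound 1 to compound 4 (0.56 log units; beyond the scatter) against 4-cyanophenyl, while a 1.7-fold higher number from compound 2 to compound 4 (0.22 log units; within the scatter) leaves it unordered against 2-cyanophenyl. No measurement at hand accounts for these steps.

The halogen and its place on the phenyl changed together in this step, so their contributions remain unseparated. As far as these compounds go, how a phenyl carrying an amine or a carboxylic acid would read here also stays open.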